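This account rests on a few compounds, and the source may have more. Where it says the series, first, only, none or still open, it means among the compounds named here.

Compound 3 `COc1ccc2nc(C)cc(OCC(=O)NCc3cc(C)cc(C)c3)c2c1` stands at the edge of what a toxicity assay on HepG2 cells (Homo sapiens) for inhibition, read by CellTiter-Glo, with a stated time of 48 h (a lower number here means a stronger inhibitor, a higher number a weaker inhibitor), reports: in this assay compound 3 gives > 100000 nM, which is a limit rather than a number. Compound 1 `COc1ccc2nc(C)cc(OCC(=O)Nc3cc(C)cc(C)c3)c2c1` gives 20000 nM in this assay. Compound 2 `CCOc1ccc2nc(C(F)(F)F)cc(OCC(=O)Nc3cc(C)cc(C)c3)c2c1` gives > 100000 nM in this assay, again a limit. Compound 4 `COc1ccc2nc(C)cc(OCC(=O)Nc3ccccc3)c2c1` differs from compound 3 by phenyl in place of 3,5-dimethylbenzyl on an amide-type nitrogen. Among the compounds with values here, the only measured step touching this position is an at least 5.0-fold higher number from compound 1 to compound 3 (0.69 log units; beyond the scatter), and compound 4 reverses that benzyl change while also dropping both methyl groups. Since two of the three values rest at the limit of > 100000 nM in this assay, at which 2 of the 3 values shown sit, compound 3 is bounded only from one side. Compound 4 is therefore expected to give 40000 nM, within a range from 15000 nM to 100000 nM. That expectation amounts to a step of an at least 2.5-fold lower number from compound 3 to compound 4 (0.39 log units; beyond the scatter), toward where compound 1 stands.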

Compound 4, half-maximal inhibitory concentration: 39800 nM
Estimate against measurement, compound 4: 1.0-fold (0.00 log units) above; the measured number falls inside the stated range.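

In this assay, phenyl on the amide-type nitrogen gives an at least 2.5-fold lower number from compound 3 to compound 4 (0.40 log units; beyond the scatter), so moving from the 3,5-dimethylbenzyl group to the directly attached ring again changes the reading. Set against 3,5-dimethylphenyl, the same phenyl gives a 2.0-fold higher number from compound 1 to compound 4 (0.30 log units; within the scatter), so losing the two methyl groups from that directly attached ring has no effect that can be told from the scatter. The value of compound 3 is a limit, so the step from it is bounded on one side only: the limit of > 100000 nM in this assay, at which 2 of the 4 values shown sit.

Going by these compounds, it remains open whether an unsubstituted benzyl group would read like compound 3 or like compound 4. On these data alone, the effect of a phenyl carrying an amine or a carboxylic acid also remains open.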